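A few compounds are considered here, and "the series" means these few. Any claim that something is new, unique, unknown or untested is made for them only; others in the source may bear on it.

Compound 1, `CCCCC(CC)n1ccc2cc(/C(C)=C/C(=O)Nc3ccccc3OCCCC(=O)O)ccc21`, gives 7.1 nM in an assay on Prostate gland for inhibition of steroid 5-alpha-reductase (Rattus norvegicus) (on this read-out lower numbers stand for stronger inhibition and higher numbers for weaker inhibition), the lowest number of the three measured compounds. Compound 2, `CCCCC(CCCC)n1ccc2cc(/C(C)=C/C(=O)Nc3ccccc3OCCCC(=O)O)ccc21`, gives 21 nM, and compound 3, `COc1ccc(Cn2ccc3cc(/C(C)=C/C(=O)Nc4ccccc4OCCCC(=O)O)ccc32)cc1`, gives 480 nM. The step to compound 4, `CCCCC(c1ccccc1)n1ccc2cc(/C(C)=C/C(=O)Nc3ccccc3OCCCC(=O)O)ccc21`, is phenyl in place of ethyl on a saturated chain carbon bound to an aromatic nitrogen and a saturated chain carbon. Going by the values given here, two measured steps bear on it: a 3.0-fold higher number from compound 1 to compound 2 (0.47 log units; beyond the scatter), where the branch on the chain carbon grew, and a 68-fold higher number from compound 1 to compound 3 (1.83 log units; beyond the scatter), where the whole branched chain gave way to an aromatic ring on the nitrogen. Compound 4 keeps the pentyl arm and adds a ring only on one branch, so a modest weakening is expected rather than the large one seen for compound 3. Compound 4 is therefore estimated at 20 nM, between 6 nM and 70 nM, a step of a 2.8-fold higher number from compound 1 to compound 4 (0.45 log units; beyond the scatter).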

Compound 4, half-maximal inhibitory concentration: 9.8 nM
Compound 4: the middle estimate sits 2.0-fold (0.31 log units) above what was measured; low and high end bracket the measured number.
By their numbers in this assay, from the lowest: compounds 1 and 4 (each within the scatter of the next); then compound 2; then compound 3.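

On the saturated chain carbon bound to an aromatic nitrogen and a saturated chain carbon, phenyl is accepted in place of ethyl (a 1.4-fold higher number from compound 1 to compound 4 (0.14 log units; within the scatter)), so a ring can sit here when the rest of the pentyl group stays. Phenyl also gives a lower number than butyl at this place (a 2.1-fold lower number from compound 2 to compound 4 (0.33 log units; beyond the scatter)), and an aromatic ring on this branch does not bring the loss seen with 4-methoxybenzyl (a 49-fold lower number from compound 3 to compound 4 (1.69 log units; beyond the scatter)). No measurement at hand accounts for these differences. The compounds shown leave open whether a pyridine ring or a cyclohexyl group on this carbon would serve as phenyl does, and whether the butyl part of 1-phenylpentyl can be shortened to a propyl or an ethyl.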